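The source may report more compounds than this note shows. Statements on the series, on what has been measured and on what is new or still open speak of the compounds shown alone.

Compound 1, `CS(=O)(=O)c1cc(C(=O)N=C(N)N)c(Cl)cc1Cl`: 140 nM
Compound 2, `Cc1c(C(=O)N=C(N)N)cc(S(C)(=O)=O)c(Cl)c1C`: 58 nM
Compound 3, `Cc1cc(-c2ccc(Cl)cc2Cl)c(S(C)(=O)=O)cc1C(=O)N=C(N)N`: 42 nM

In a functional assay for inhibition of sodium/hydrogen exchanger (Oryctolagus cuniculus) (on this read-out lower numbers stand for stronger inhibition and higher numbers for weaker inhibition), compound 3 shows the lowest of the three numbers. Its nearest neighbour is compound 2, whose number is higher by an amount that lies within the usual scatter, so the two cannot be told apart on this evidence. The furthest is compound 1, whose number is higher by an amount beyond the scatter, so compound 3 stands clearly apart from compound 1 but not from compound 2.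

Compound 4, `Cc1cc(OC(C)(C)C)c(S(C)(=O)=O)cc1C(=O)N=C(N)N`, has not yet been measured. It differs from compound 3 in one place: tert-butoxy in place of 2,4-dichlorophenyl on an aromatic carbon. Going by the values given here, no pair of measured compounds differs in only one place, so no single step of known size is available to guide the expectation, and the change itself, tert-butoxy in place of 2,4-dichlorophenyl, has no measured counterpart among compounds 1 to 3.

On that footing the step from compound 3 to compound 4 is expected to be small, with a slight lean toward a higher number, estimated as a 1.5-fold higher number from compound 3 to compound 4 (0.19 log units; within the scatter). Compound 4 is therefore expected to give about 65 nM in this assay, within a range from 25 nM to 170 nM.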

Compound 4, half-maximal inhibitory concentration: 9.4 nM
For compound 4 the middle estimate is 6.9-fold (0.84 log units) above the measured one, and the stated range ends above it.
By their numbers in this assay, from the lowest: compound 4; then compounds 3 and 2 (each within the scatter of the next); then compound 1.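

In this assay the exchange of 2,4-dichlorophenyl for tert-butoxy, on the aromatic carbon ortho to a methylsulfonyl group, gives a 4.5-fold lower number from compound 3 to compound 4 (0.65 log units; beyond the scatter) and so moves the number beyond the usual scatter. Going by these compounds alone, this is the first single-place comparison, and it shows that an aromatic ring is not needed at this position for a low number, since the entering group has no ring and the leaving group does. Nothing measured on these compounds accounts for the size or direction of this step.

This one exchange removes the ring, reduces the heavy-atom count and brings in an ether oxygen all at once, so the compounds shown leave open which of these changes carries the step, and a phenoxy group, an isopropoxy group or a plain tert-butyl group on the same carbon would help to separate them. On these data alone, it also remains open whether tert-butoxy would have a similar effect on a core with different neighbouring substituents, such as those of compound 1 or compound 2.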